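The source may report more compounds than this note shows. Statements on the series, on what has been measured and on what is new or still open speak of the compounds shown alone.

Working notes on the series. In an ADME assay on HEK293 cells (Homo sapiens) for cytotoxicity, read by CCK-8 assay and cell counting, with a stated time of 2 days (on this read-out higher numbers stand for weaker inhibition and lower numbers for stronger inhibition), compound 1 `Oc1ccc(-c2cc(-c3cccc(Cl)c3)nc(-c3ccccn3)c2)cc1` gives 25400 nM and compound 3 `Oc1cccc(-c2cc(-c3ccc(Cl)cc3)nc(-c3ccccn3)c2)c1` gives 14000 nM; the gap between these two values lies within the usual scatter, so no order between them is read. Compound 2 `Oc1cccc(-c2cc(-c3cccc(Cl)c3)nc(-c3ccccn3)c2)c1` shares the core and carries the 3-hydroxyphenyl and 3-chlorophenyl groups of compound 3, but in this assay compound 2 gives "not determined" (no result reported), so it stands without a number of its own. Compound 4 `Oc1cccc(-c2cc(-c3ccsc3)nc(-c3cccc(Cl)c3)c2)c1` is not yet measured and differs from compound 2 by thiophen-3-yl in place of pyridin-2-yl on an aromatic carbon. Without a measured anchor for compound 2, the expected step in this assay is none beyond the scatter, in either direction, judged only from the two values shown for compound 1 and compound 3. Compound 4 is therefore expected to give about 19000 nM in this assay, estimated within the range 7000 nM to 55000 nM.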

Compound 4, half-maximal inhibitory concentration: 3180 nM
Compound 4: middle estimate off by 6.0-fold (0.78 log units), on the high side, and the stated range ends above it.
By their numbers in this assay, from the lowest: compound 4; then compounds 3 and 1 (each within the scatter of the next).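

Among the compounds shown here, compound 2 has no number in this assay and no step from it to compound 4 can be read. The compounds shown leave open what thiophen-3-yl in place of pyridin-2-yl alone does to this read-out. No evidence at hand bears on the result.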